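The compounds below may be only part of what the source reports. "The series", "measured", "known", "first", "only" and "open" are said of these compounds alone.

Measured so far in a functional assay on cells for positive allosteric modulation of G-protein coupled receptor 68 (Homo sapiens), read by a luciferase reporter and cAMP accumulation, with a stated time of 30 min, at pH 6.8 and pH 8.3, in the presence of a further agent that is not named here; a lower number here means a less potent compound, a higher number a more potent compound, by a factor of ten per unit of this negative logarithm:
compound 1 `Nc1nc(NCc2ccc(F)cc2)nc(-c2ccccc2CO)n1`: 3.97
compound 2 `COc1ccccc1CNc1nc(N)nc(-c2ccccc2CO)n1`: 3.99

Compound 2 and compound 1 lie within the scatter of each other, so neither stands apart. Going by the values given here, the only measured step, a number 0.02 log units higher from compound 1 to compound 2 (within the scatter), changes the aryl group on the saturated chain carbon without effect beyond the scatter.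

Compound 3 `COc1ccc(CNc2nc(N)nc(-c3ccccc3CO)n2)cc1` differs from compound 2 by 4-methoxyphenyl in place of 2-methoxyphenyl on a saturated chain carbon bound to a nitrogen on an aromatic ring. Among the compounds with values here, no measured step moves a methoxy group from one ring position to another, so the single aryl swap above is the only guide, and it was flat. In this assay compound 3 is therefore expected near compound 2, with an estimated step of a number 0.01 log units higher from compound 2 to compound 3 (within the scatter). The estimate for compound 3 is 4, expected to fall between 3.6 and 4.4.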

Compound 3, negative logarithm of the antagonist equilibrium constant: 3.34
Compound 3: the middle estimate sits 0.66 log units above what was measured, outside the stated range (below it).
By their numbers in this assay, from the lowest: compound 3; then compounds 1 and 2 (each within the scatter of the next).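

Moving the methoxy group on the saturated chain carbon bound to a nitrogen on an aromatic ring is not neutral in this assay (a number 0.65 log units lower from compound 2 to compound 3 (beyond the scatter)), so the earlier flat aryl swap does not show that this place tolerates any change. The 4-methoxyphenyl group also falls short of the 4-fluorophenyl group (a number 0.63 log units lower from compound 1 to compound 3 (beyond the scatter)), so the choice of group on that aromatic carbon counts as well. No measurement here accounts for this difference.

Open, going by these compounds, is how unsubstituted phenyl, 4-chlorophenyl or 4-aminophenyl would read in this place. Also open, on these data alone, is whether a longer chain to the aryl group would keep the numbers of compound 1 and compound 2.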